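Swapping a morpholine amide for an acid on two cores

The source may report more compounds than this note shows. Statements on the series, on what has been measured and on what is new or still open speak of the compounds shown alone.

Compound 1 `O=C(COc1ccncc1-c1ccc2ccccc2c1)N1CCOCC1` and compound 2 `O=C(O)COc1ccncc1-c1ccc2ccccc2c1` share one core, while compound 3 `Cn1ccc2cc(-c3cnccc3/C=C/C(=O)N3CCOCC3)ccc21` and compound 4 `Cn1ccc2cc(-c3cnccc3/C=C/C(=O)O)ccc21` share another; the difference between the two cores is not broken down here. In an assay on a protein complex for inhibition of CDK8/Cyclin C (Homo sapiens), with a stated time of 1 h, tested at 10 uM (on this read-out lower numbers stand for less inhibition and higher numbers for more inhibition at the one concentration tested (going by the name of the read-out)), compound 1 gives 9%, and compound 2 gives 16%. The change between them is hydroxy in place of morpholin-4-yl on a carbonyl carbon, and it gave a number 7 percentage points higher from compound 1 to compound 2 (within the scatter). Compound 3 gives 97% in this assay, far above compound 1 and compound 2. Compound 4 carries the same kind of change as compound 2, namely (hydroxy in place of morpholin-4-yl on a carbonyl carbon); here the carbonyl carbon sits on a double-bonded chain carbon rather than on a saturated chain carbon, so the surroundings of the place differ. Only these two examples of the change exist among the four compounds, so no wider pattern can be drawn. Because the step from compound 1 to compound 2 was a number 7 percentage points higher from compound 1 to compound 2 (within the scatter), the step from compound 3 to compound 4 in this assay is expected to be similarly modest, at a number 17 percentage points lower from compound 3 to compound 4 (beyond the scatter), though the different surroundings and the high starting point of compound 3 leave room for a larger drop. Compound 4 is therefore estimated at 80%, between 45% and 97%.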

Compound 4, a percentage reported as inhibition, at one concentration (the size of the read-out at that concentration, not a potency): 102%
Compound 4: the middle estimate sits 22 percentage points below what was measured; measured number outside the range, above it.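

In this assay, putting hydroxy in place of morpholin-4-yl on the carbonyl carbon, which turns the (morpholin-4-yl)carbonyl into a carboxy group, gave a number 5 percentage points higher from compound 3 to compound 4 (within the scatter). Set beside the earlier step, the change carried from one core to the other with no visible difference in its effect: the same change on two cores in this assay, a number 7 percentage points higher (within the scatter) from compound 1 to compound 2 and a number 5 percentage points higher (within the scatter) from compound 3 to compound 4, 2 percentage points apart, within the scatter of two such steps. Among these compounds, this does not show that the swap makes no difference in general: it rests on only two pairs, and with compound 3 at 97% and compound 4 at 102%, a reading at one concentration, which is not a potency, could hide a real difference between them.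

The compounds shown leave open whether a methyl ester, a primary amide or a piperidine amide on the same carbonyl carbon, or a longer chain leading to it, would fit the same picture. Which difference between the two cores matters for this read-out also stays open: no single-place step links them.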